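The compounds below may be only part of what the source reports. "The series", "measured", "known", "first", "only" and "open" are said of these compounds alone.

In a functional assay on A549 cells (Homo sapiens) for cytotoxicity, read by MTT assay, with a stated time of 24 h (on this read-out higher numbers stand for weaker inhibition and lower numbers for stronger inhibition), compound 1, `C=CC1=C(C(=O)Nc2ccc(OCC)cc2)C(c2ccc(OC)cc2)OC1`, gives 17600 nM. Compound 2, `C=CC1=C(C(=O)Nc2ccccc2)C(c2ccc(OC)cc2)OC1`, differs from it by hydrogen in place of ethoxy on an aromatic carbon. In this assay compound 2 reaches only > 100000 nM, which is a limit of the assay and not a number. The step of an at least 5.6-fold higher number from compound 1 to compound 2 (0.75 log units; beyond the scatter) therefore shows that removing the ethoxy group weakens the compound, and its size can be stated only as a lower bound because compound 2 sits at the limit of > 100000 nM in this assay, at which 1 of the 2 values shown sits.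

Compound 3, `C=CC1=C(C(=O)NC2CCCCC2)C(c2ccc(OC)cc2)OC1`, has not yet been measured. It differs from compound 2 by cyclohexyl in place of phenyl on an amide-type nitrogen, so that anilino becomes cyclohexylamino. Among the measured compounds shown here, no measured step touches this part of the molecule: the single measured step concerns a substituent on the aromatic ring that compound 3 no longer carries. With compound 2 itself standing at a limit, the starting point is uncertain. Compound 3 is therefore expected to stay near compound 2, with an estimate of 100000 nM, between 30000 nM and 300000 nM, and an expected step of a number no higher from compound 2 to compound 3 (the limit leaves the size open).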

Compound 3, half-maximal inhibitory concentration: > 100000 nM
Compound 3 was reported as a limit; the forecaster's own chance of this, stated with the estimate: 60%; the middle value lies on the limit itself.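

In this assay, replacing the whole 4-ethoxyphenyl group on the amide-type nitrogen with cyclohexyl gives an at least 5.6-fold higher number from compound 1 to compound 3 (0.75 log units; beyond the scatter). Compound 1 therefore remains the only one of the three with a measured number, and a plain six-membered carbon ring on this nitrogen, whether aromatic as in compound 2 or non-aromatic as in compound 3, does not recover a readable value in this assay. The step between compound 2 and compound 3 cannot be read, and phenyl and cyclohexyl cannot be ranked against each other, because both compounds stand at the assay's limit: the limit of > 100000 nM in this assay, at which 2 of the 3 values shown sit.

The compounds shown leave open whether the ethoxy group needs an aromatic ring beneath it, since 4-ethoxycyclohexyl is not among them and the cyclohexyl of compound 3 carries no substituent. They also leave open whether a different group in the place of that ethoxy, such as a methoxy group, a longer alkoxy chain, an amine or a carboxylic acid, would give a value like that of compound 1 or a limit like those of compound 2 and compound 3.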